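The compounds below may be only part of what the source reports. "The series", "measured", "known", "first", "only" and "open" are said of these compounds alone.

In a functional assay on PC-3 cells (Homo sapiens) for inhibition, read by MTT assay, with a stated time of 48 h, tested at 10 uM (a lower number here means less inhibition of growth, a higher number more inhibition of growth at the concentration tested), compound 1 `Cc1oc2c([C@H]3CCN(C)C[C@H]3O)c(O)cc(O)c2c(=O)c1C(O)c1cccc(Cl)c1` gives 31%, while compound 2 `Cc1oc2c([C@H]3CCN(C)C[C@H]3O)c(O)cc(O)c2c(=O)c1C(O)c1c(F)cccc1Cl` gives 0%, the lower of the two numbers. Compound 3 `Cc1oc2c([C@H]3CCN(C)C[C@H]3O)c(O)cc(O)c2c(=O)c1C(O)c1cccc(Cl)c1Cl` is still unmeasured. Its structural change from compound 2 is 2,3-dichlorophenyl in place of 2-chloro-6-fluorophenyl on a saturated chain carbon bound to an aromatic carbon and an oxygen on a saturated carbon: 2,3-dichlorophenyl in place of 2-chloro-6-fluorophenyl. Among the compounds with values here, the only measured step bearing on this is a number 31 percentage points lower from compound 1 to compound 2 (beyond the scatter), a large one that brought in the 2-chloro-6-fluorophenyl now leaving. Given that step, a moderate rise is expected in this assay, estimated as a number 20 percentage points higher from compound 2 to compound 3 (beyond the scatter). For compound 3 the expected value is 20%, with an estimated range of 3% to 42%.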

Compound 3, percent growth inhibition at one concentration: 20%
Compound 3: the middle estimate sits on the measured number at the digits printed; measured number inside the range.
By their numbers in this assay, from the lowest: compound 2; then compound 3; then compound 1.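

In this assay the exchange of rings gives a number 20 percentage points higher from compound 2 to compound 3 (beyond the scatter) and shows that a ring carrying two halogens at this place need not lose all growth inhibition. Chloro in place of hydrogen on an aromatic carbon gives a number 11 percentage points lower from compound 1 to compound 3 (beyond the scatter) and shows that adding a second chlorine to the 3-chlorophenyl lowers the number without abolishing it. Nothing available explains either step. Going by these compounds, whether the fluorine or the arrangement of the halogens sets compound 2 apart stays open, as does how a methoxy group or an amine on this ring would read.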